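The source may report more compounds than this note shows. Statements on the series, on what has been measured and on what is new or still open speak of the compounds shown alone.

Compounds measured in a functional assay on SMMC-7721 cells (Homo sapiens) for inhibition, read by CCK-8 assay, with a stated time of 72 h, tested at 8 uM; on this read-out lower numbers stand for less inhibition of growth and higher numbers for more inhibition of growth at the one concentration tested:
compound 1 `Nc1ccccc1NC(=O)c1ccc(CSc2ccc(Br)cc2)cc1` with 25.3%;
compound 2 `COc1ccc(SCc2ccc(C(=O)Nc3ccccc3N)cc2)cc1` with 80.1%;
compound 3 `Nc1ccccc1NC(=O)c1ccc(CSc2cccc(F)c2)cc1` with 83%.

Compound 3 carries the largest of the three numbers, but the step of a number 2.9 percentage points higher from compound 2 to compound 3 (within the scatter) is within the scatter, so the two cannot be told apart, while compound 1 lies far behind, as a number 57.7 percentage points higher from compound 1 to compound 3 (beyond the scatter) shows. Compound 4 `Cc1cc(C)cc(SCc2ccc(C(=O)Nc3ccccc3N)cc2)c1` differs from compound 3 in one place: 3,5-dimethylphenyl in place of 3-fluorophenyl on a sulfur. Going by the values given here, two measured steps bear on this change, since both alter the group on the sulfur. The step of a number 57.7 percentage points higher from compound 1 to compound 3 (beyond the scatter) and the step of a number 54.8 percentage points higher from compound 1 to compound 2 (beyond the scatter) show that leaving the bromo case brings a large rise, whereas a number 2.9 percentage points higher from compound 2 to compound 3 (within the scatter) shows that exchanging one non-bromo aryl group for another leaves the number where it was. The group entering in compound 4 is not the bromo case, so compound 4 is expected to stay close to compound 3, with a step of a number 7 percentage points lower from compound 3 to compound 4 (within the scatter). Compound 4 is therefore estimated at 76%, within a range from 52% to 92%.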

Compound 4, percent growth inhibition at one concentration: 85.1%
The estimate for compound 4 lay 9.1 percentage points below the measured number; the measured number falls inside the stated range.
By their numbers in this assay, from the lowest: compound 1; then compounds 2, 3 and 4 (each within the scatter of the next).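

In this assay, the step of a number 2.1 percentage points higher from compound 3 to compound 4 (within the scatter) and the step of a number 5 percentage points higher from compound 2 to compound 4 (within the scatter) both lie within the scatter, so 3,5-dimethylphenyl on the sulfur, with 8 heavy atoms, all carbon, cannot be told apart from 3-fluorophenyl or 4-methoxyphenyl. The step of a number 59.8 percentage points higher from compound 1 to compound 4 (beyond the scatter) is large, which makes compound 1, with its 4-bromophenyl, the only one of the four set apart, now against three different groups on the sulfur rather than two. Nothing available explains why the 4-bromophenyl compound stands apart.

The compounds shown leave open whether that gap belongs to bromo alone, as a 4-chlorophenyl or 3-bromophenyl group on the sulfur could test. They also leave open how an aryl group carrying an amine or a carboxylic acid, or a longer alkyl chain in place of the aryl group, would read here.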